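The source may hold more compounds than are shown below. What is called first, only, known or untested is meant among the compounds shown, and "the series" means these compounds.

Measured so far in a functional assay on LNCaP cells (Homo sapiens) for antiproliferative activity, read by MTT assay, with a stated time of 3 days (on this read-out lower numbers stand for stronger inhibition and higher numbers for weaker inhibition), with these results:
- compound 1 `COc1cc(O)c2c(=O)cc(-c3ccc(NS(C)(=O)=O)cc3)oc2c1OC(C)C` gives 15400 nM
- compound 2 `CCS(=O)(=O)Nc1ccc(-c2cc(=O)c3c(O)cc(OC)c(OC(C)C)c3o2)cc1` gives 113000 nM
- compound 3 `COc1cc(O)c2c(=O)cc(-c3ccc(NC(=O)N4CCCNCC4)cc3)oc2c1OC(C)C` gives 22500 nM

The standing of compound 3 rests on two gaps: a 1.5-fold higher number from compound 1 to compound 3 (0.16 log units; within the scatter) on the near side and a 5.0-fold lower number from compound 2 to compound 3 (0.70 log units; beyond the scatter) on the far side.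

The next compound is compound 4 `COc1cc(O)c2c(=O)cc(-c3ccc(NC(=O)N4CC(C)NC(C)C4)cc3)oc2c1OC(C)C`. The change is 3,5-dimethylpiperazin-1-yl in place of 1,4-diazepan-1-yl on a carbonyl carbon on a carbonyl carbon, so 3,5-dimethylpiperazin-1-yl stands in place of 1,4-diazepan-1-yl.

Among the compounds with values here, no measured step makes this ring exchange, so the data offer no direct guide. Within the data shown here, two steps bear on it indirectly. Compound 3 carries a wholly different group on the aromatic nitrogen from compound 1, yet the result is a 1.5-fold higher number from compound 1 to compound 3 (0.16 log units; within the scatter) and that larger replacement stays small in effect. Compound 2 adds only a methyl to compound 1, and the result is a 7.3-fold higher number from compound 1 to compound 2 (0.87 log units; beyond the scatter) as a warning that a small addition can still produce a modest rise.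

Taken together, these point to little change, with any drift expected toward a higher number. The estimated step in this assay is a 1.2-fold higher number from compound 3 to compound 4 (0.08 log units; within the scatter) and no clear move beyond the scatter is expected.

For compound 4 the estimated value is 27000 nM with an expected range from 10000 nM to 75000 nM for the measurement still to come.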

Compound 4, half-maximal inhibitory concentration: 2800 nM
Compound 4: the middle estimate sits 9.6-fold (0.98 log units) above what was measured; measured number outside the range, below it.
By their numbers in this assay, from the lowest: compound 4; then compounds 1 and 3 (each within the scatter of the next); then compound 2.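

In this assay, the group on the carbonyl carbon proves to be a position where the result moves: exchanging 1,4-diazepan-1-yl for 3,5-dimethylpiperazin-1-yl gives a step beyond the scatter (an 8.0-fold lower number from compound 3 to compound 4 (0.91 log units; beyond the scatter)). The earlier compounds shown here showed only that the (1,4-diazepan-1-yl)carbonyl group and methylsulfonyl stood within the scatter of each other on the aromatic nitrogen, whereas (3,5-dimethylpiperazin-1-yl)carbonyl clearly separates from both sulfonyl groups (a 5.5-fold lower number from compound 1 to compound 4 (0.74 log units; beyond the scatter)) and (a 40-fold lower number from compound 2 to compound 4 (1.61 log units; beyond the scatter)), and compound 4 now has the lowest number of the series. Nothing available here accounts for the effect of this ring exchange.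

The exchange alters ring size and adds two methyl groups in a single step, so the compounds shown leave open which of the two changes carries the drop; a plain piperazin-1-yl group on the same carbonyl carbon would separate them. Also open, as far as these compounds go, is whether the gain depends on the free ring amine hydrogen, which a 4-methylpiperazin-1-yl or a morpholin-4-yl group in that place would address.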